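The source may report more compounds than this note shows. Statements on the series, on what has been measured and on what is new or still open speak of the compounds shown alone.

Working notes on the series. In a physicochemical assay on cells (Homo sapiens), with a stated time of 18 h, tested at 1 uM (on this read-out higher numbers stand for a weaker effect at the one concentration tested and lower numbers for a stronger effect), compound 3 `COc1cc(/C=N/Nc2nc3ccccc3s2)ccc1O` gives 65%, the highest of the three numbers; compound 2 `Oc1ccc(/C=N/Nc2nc3ccccc3s2)cc1O` gives 44% and compound 1 `COc1cc(/C=N/N(C)c2nc3ccccc3s2)cc(OC)c1O` gives 5%. Among the compounds with values here, the only single-place step measured is a number 21 percentage points higher from compound 2 to compound 3 (beyond the scatter). Compound 4 `COc1cc(/C=N/N(C)c2nc3ccccc3s2)ccc1O` differs from compound 3 by methyl in place of hydrogen on a nitrogen on an aromatic ring. Within the data shown here, no measured step bears directly on this change; compound 1 carries the same methyl on the nitrogen and shows the lowest number of the set, though it also differs from compound 4 elsewhere, so it is only a loose pointer. Compound 4 is therefore expected to give 25%, within 5% to 55%, a step of a number 40 percentage points lower from compound 3 to compound 4 (beyond the scatter) expected downward.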

Compound 4, a percentage reported as activity, at one concentration (the size of the read-out at that concentration, not a potency): 20%
Compound 4: middle estimate off by 5 percentage points, on the high side; low and high end bracket the measured number.
By their numbers in this assay, from the lowest: compound 1; then compound 4; then compound 2; then compound 3.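

In this assay, within the data shown here, methyl in place of hydrogen on a nitrogen on an aromatic ring gives a number 45 percentage points lower from compound 3 to compound 4 (beyond the scatter), the first direct reading of this change. With that methyl kept, hydrogen in place of methoxy on an aromatic carbon gives a number 15 percentage points higher from compound 1 to compound 4 (beyond the scatter), so the methoxy also registers on this background. Nothing measured on the mechanism accompanies either step. Open, on these data alone, is whether an ethyl group or a longer chain on that nitrogen follows the methyl, and whether the methyl step recurs with the core of compound 2 .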